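The compounds below may be only part of what the source reports. "The series", "measured", "known", "first", "only" and "open" are said of these compounds alone.

The compounds measured so far:
compound 1, `COC(=O)[C@@]1(C)CCC=C2[C@@H]1CC[C@@H](C)[C@]2(C)Cc1c(C)[nH]c2ccccc12`, 11000 nM
compound 2, `COC(=O)[C@@]1(C)CCC=C2[C@@H]1CC[C@@H](C)[C@]2(C)Cc1c(C)[nH]c2ccc(F)cc12`, 11000 nM

In a functional assay on HeLa cells (Homo sapiens) for inhibition, read by sulforhodamine B assay, with a stated time of 48 h (a lower number here means a stronger inhibitor of growth, a higher number a weaker inhibitor of growth), compound 2 gives 11000 nM. Within the data shown here, its only measured neighbour is compound 1, and the step of no change at the digits printed from compound 1 to compound 2 (within the scatter) shows that adding fluoro on the aromatic carbon left the read-out where it was. Compound 2 therefore stands level with compound 1, with nothing between them beyond the scatter.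

Compound 3, `COC(=O)[C@@]1(C)CCC=C2[C@@H]1CC[C@@H](C)[C@]2(C)Cc1c(C)[nH]c2ccc(OC)cc12`, differs from compound 2 in one place: methoxy in place of fluoro on an aromatic carbon. Among the measured compounds shown here, the only measured step that touches this position is no change at the digits printed from compound 1 to compound 2 (within the scatter), and it was flat. Methoxy is a larger group than fluoro, carrying one hydrogen-bond acceptor where fluoro carried none, so that flat step is only a partial guide, and no measured pair speaks for either direction. The expectation is that the change again leaves the read-out within the scatter of compound 2.

Compound 3 is expected to give 11000 nM in this assay, with a range from 5000 nM to 25000 nM. This estimate means a step of no change at the digits printed from compound 2 to compound 3 (within the scatter), expected to be nothing beyond the scatter.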

Compound 3, concentration for 50% growth inhibition: 12000 nM
Estimate against measurement, compound 3: 1.1-fold (0.04 log units) below, within the range that was stated.
By their numbers in this assay, from the lowest: compounds 1, 2 and 3 (each within the scatter of the next).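

In this assay, the aromatic carbon that is meta to a fused ring and para to a fused ring has now been read with hydrogen, fluoro and methoxy, and the read-out does not move beyond the scatter with any of them (a 1.1-fold higher number from compound 2 to compound 3 (0.04 log units; within the scatter); a 1.1-fold higher number from compound 1 to compound 3 (0.04 log units; within the scatter)). The earlier pair showed this only for fluoro in place of hydrogen, whereas this result extends it to methoxy, which brings more heavy atoms than fluoro and a hydrogen-bond acceptor, so across these three compounds neither of those differences shifts the number. No measurement at hand accounts for this flat behaviour.

The compounds shown leave open whether any group on this carbon can shift the number at all, since an amine, a carboxylic acid or a longer chain such as butoxy has no value here. They also say nothing about the rest of the shared core, for instance whether a carboxylic acid in place of the methyl ester would change the read-out, as all three compounds carry the same ester.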